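A few compounds are considered here, and "the series" means these few. Any claim that something is new, unique, unknown or untested is made for them only; others in the source may bear on it.

Compound 1, `CC1(C)Cc2c(sc(NC(=O)c3ccn[nH]3)c2C(N)=O)C(C)(C)O1`, gives 339 nM in an assay on cells for positive allosteric modulation of Cystic fibrosis transmembrane conductance regulator variant G551D (Homo sapiens), with stated times of 10 min and 2 min, in the presence of a further agent that is not named here; a higher number here means that more compound is needed for the effect, a lower number that less compound is needed.
Compound 2, `CC1(C)Cc2c(sc(NC(=O)c3[nH]ncc3Cl)c2C(N)=O)C(C)(C)O1`, gives 81 nM in this assay.
Compound 3, `Cc1cc(C(=O)Nc2sc3c(c2C(N)=O)CC(C)(C)OC3(C)C)[nH]n1`, gives 590 nM in this assay.

All three share one core and differ only in the small five-membered aromatic ring that sits on the carbonyl. Compound 2 differs from compound 1 by chloro in place of hydrogen on an aromatic carbon, and this change gave a 4.2-fold lower number from compound 1 to compound 2 (0.62 log units; beyond the scatter). Compound 2 and compound 3 differ in the whole of that ring, and here a 7.3-fold higher number from compound 2 to compound 3 (0.86 log units; beyond the scatter).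

Compound 4, `Cc1n[nH]c(C(=O)Nc2sc3c(c2C(N)=O)CC(C)(C)OC3(C)C)c1Cl`, has not yet been measured in this assay. It differs from compound 3 by chloro in place of hydrogen on an aromatic carbon. Among the compounds with values here, this is the same kind of change as the one from compound 1 to compound 2, but not the same: in compound 4 the place is also next to the ring atom that bears a methyl group, which compound 2 lacks. The two cores differ by methyl in place of hydrogen on an aromatic carbon, a change that gave a 1.7-fold higher number from compound 1 to compound 3 (0.24 log units; within the scatter), within the scatter.

Because the first chloro step gave a 4.2-fold lower number from compound 1 to compound 2 (0.62 log units; beyond the scatter) in this assay, a step of roughly similar size is expected from compound 3 to compound 4, a 3.5-fold lower number from compound 3 to compound 4 (0.54 log units; beyond the scatter), with some allowance for the methyl now standing at the place. Compound 4 is therefore expected to give about 170 nM in this assay, most likely between 70 nM and 400 nM.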

Compound 4, half-maximal effective concentration: 199 nM
Compound 4: the middle estimate sits 1.2-fold (0.07 log units) below what was measured, within the range that was stated.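

The chloro step on the methyl-bearing ring, a 3.0-fold lower number from compound 3 to compound 4 (0.47 log units; beyond the scatter), matches the earlier chloro step in this assay, so this change carried over from one ring to the other: the same change on two cores in this assay, a 4.2-fold lower number (0.62 log units; beyond the scatter) from compound 1 to compound 2 and a 3.0-fold lower number (0.47 log units; beyond the scatter) from compound 3 to compound 4, 1.4-fold (0.15 log units) apart, within the scatter of two such steps

The methyl step, a 2.5-fold higher number from compound 2 to compound 4 (0.39 log units; beyond the scatter), likewise matches its earlier counterpart, so in these four compounds the two changes behave as if each adds its own effect, with no sign that one alters the other: the same change on two cores in this assay, a 1.7-fold higher number (0.24 log units; within the scatter) from compound 1 to compound 3 and a 2.5-fold higher number (0.39 log units; beyond the scatter) from compound 2 to compound 4, 1.4-fold (0.15 log units) apart, within the scatter of two such steps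

With both changes together the result is a 1.7-fold lower number from compound 1 to compound 4 (0.23 log units; within the scatter), so compound 4 cannot be told apart from compound 1, and this additive reading rests on just these four compounds, which show only that chloro and methyl carry over on this one small ring, not that other groups or other cores would behave the same way.

As far as these compounds go, it remains open whether a larger halogen such as bromine, or a nitrile, would give a similar step in place of the chloro, and whether an ethyl group or a longer chain would leave the chloro step unchanged in place of the methyl. From the compounds shown here alone, the shared core is also the same throughout, so whether the chloro step holds on a different core is unknown.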